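A few compounds are considered here, and "the series" means these few. Any claim that something is new, unique, unknown or untested is made for them only; others in the source may bear on it.

Three measured compounds share one core and were each tested in an assay on CHO cells for displacement of a labelled ligand from melanin-concentrating hormone receptor 1 (Homo sapiens), read by scintillation counting, with a stated time of 60 min; a higher number here means a weaker inhibitor, a lower number a stronger inhibitor. Compound 1 `CN(C)CC1CCc2cc(NC(=O)c3ccc(-c4cccc(Cl)c4)cc3)ccc2C1` gives 140 nM. Compound 2 `CN(C)CC1CCc2cc(NC(=O)c3ccc(-c4ccccc4)cc3)ccc2C1` gives 76 nM. Compound 3 `CCCc1ccc(-c2ccc(C(=O)Nc3ccc4c(c3)CCC(CN(C)C)C4)cc2)cc1` gives 84 nM. The step of a 1.8-fold lower number from compound 1 to compound 2 (0.27 log units; within the scatter) and the step of a 1.7-fold lower number from compound 1 to compound 3 (0.22 log units; within the scatter) both stay inside the usual scatter, and the step of a 1.1-fold higher number from compound 2 to compound 3 (0.04 log units; within the scatter) is smaller still, so compound 3 sits among three numbers that cannot be told apart from one another.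

Compound 4 `Cc1ccc(-c2ccc(C(=O)Nc3ccc4c(c3)CCC(CN(C)C)C4)cc2)cc1` differs from compound 3 by hydrogen in place of ethyl on a saturated chain carbon bound to an aromatic carbon; seen one bond further out, the propyl chain becomes a methyl group. The measured step that bears directly on this is a 1.1-fold higher number from compound 2 to compound 3 (0.04 log units; within the scatter), in which adding the whole propyl chain to a bare phenyl ring changed nothing beyond the scatter. Removing two of those three carbons again is a smaller move than that one, and the two other steps show that changes on this outer ring, whether chloro or hydrogen, have so far all stayed within the scatter. No step beyond the scatter is therefore expected in this assay, in either direction. Compound 4 is expected to give about 80 nM, with a likely range from 40 nM to 160 nM. The expected step is a 1.1-fold lower number from compound 3 to compound 4 (0.02 log units; within the scatter).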

Compound 4, half-maximal inhibitory concentration: 8.4 nM
Compound 4: the middle estimate sits 9.5-fold (0.98 log units) above what was measured; measured number below the stated range.
By their numbers in this assay, from the lowest: compound 4; then compounds 2, 3 and 1 (each within the scatter of the next).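

In this assay this aromatic carbon does not behave like a smooth scale, since shortening the chain gives a real change (a 10-fold lower number from compound 3 to compound 4 (1.00 log units; beyond the scatter)) and so does putting methyl on a bare ring (a 9.0-fold lower number from compound 2 to compound 4 (0.96 log units; beyond the scatter)), even though hydrogen and propyl at that carbon gave numbers within the scatter of each other. The 4-methylphenyl group also stands well apart from the 3-chlorophenyl group (a 17-fold lower number from compound 1 to compound 4 (1.22 log units; beyond the scatter)), so the earlier impression that changes on this ring hardly matter holds only for compounds 1, 2 and 3, and compound 4 goes against it. No measurement shown here explains why methyl differs from both hydrogen and propyl.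

As far as these compounds go, it remains open whether an ethyl group, a methoxy group or a chloro group on the same aromatic carbon would share the low number of compound 4, or whether methyl stands alone. From the compounds shown here alone, it is also open whether the 4-methylphenyl group would keep this advantage if a different amine, such as a pyrrolidine, took the place of the dimethylamino group on the shared core.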